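Swapping a flexible chain for a difluorophenyl amide

The compounds below may be only part of what the source reports. "The series", "measured", "known", "first", "only" and "open" are said of these compounds alone.

Measured compounds:
Compound 1 `CCCCC(=O)Nc1ccc(N2CCN(c3ccc(OC[C@@H]4CO[C@@](Cn5cncn5)(c5ccc(Cl)cc5Cl)O4)cc3)CC2)cc1`: 14100 nM
Compound 2 `O=C(CCCc1ccccc1)Nc1ccc(N2CCN(c3ccc(OC[C@@H]4CO[C@@](Cn5cncn5)(c5ccc(Cl)cc5Cl)O4)cc3)CC2)cc1`: 10800 nM

In a functional assay on HepG2 cells (Homo sapiens) for inhibition, read by MTT assay, with a stated time of 48 h (on this read-out lower numbers stand for stronger inhibition and higher numbers for weaker inhibition), compound 1 gives 14100 nM, and compound 2 gives 10800 nM. Compound 2 has the lower of the two numbers, but the step of a 1.3-fold lower number from compound 1 to compound 2 (0.12 log units; within the scatter) is within the scatter, so the two compounds cannot be told apart on this read-out. Compound 3 `O=C(Nc1ccc(N2CCN(c3ccc(OC[C@@H]4CO[C@@](Cn5cncn5)(c5ccc(Cl)cc5Cl)O4)cc3)CC2)cc1)c1ccc(F)c(F)c1` carries 3,4-difluorophenyl in place of 3-phenylpropyl on a carbonyl carbon. Among the measured compounds shown here, only one step bears on this change, a 1.3-fold lower number from compound 1 to compound 2 (0.12 log units; within the scatter), which altered the same chain by adding a phenyl at its far end; no measured step exchanges a chain on the carbonyl carbon for an aromatic ring directly attached to it. That single step was small, so no move beyond the scatter is expected in this assay for compound 3, in either direction. Compound 3 is expected to give 9500 nM, within 3000 nM to 30000 nM, corresponding to an estimated step of a 1.1-fold lower number from compound 2 to compound 3 (0.06 log units; within the scatter).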

Compound 3, half-maximal inhibitory concentration: 19900 nM
Compound 3: middle estimate off by 2.1-fold (0.32 log units), on the low side, and the stated range covers the measured number.
By their numbers in this assay, from the lowest: compounds 2, 1 and 3 (each within the scatter of the next).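

In this assay, a 3,4-difluorophenyl ring attached directly to the carbonyl carbon stays within the scatter of both chains: replacing 3-phenylpropyl gives a 1.8-fold higher number from compound 2 to compound 3 (0.27 log units; within the scatter), and replacing butyl gives a 1.4-fold higher number from compound 1 to compound 3 (0.15 log units; within the scatter). The earlier pair changed only the far end of a chain, whereas these steps show that this position can also hold an aromatic ring directly on the carbonyl carbon with no change that this read-out can resolve. Nothing measured here offers a reason for this flat result.

Going by these compounds, it remains open whether a plain phenyl ring on the carbonyl carbon would read the same as the 3,4-difluorophenyl ring. On these data alone, it is also open whether an amine or a carboxylic acid at the end of the chain would move the number beyond the scatter.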